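A Smaller Ring With a Second Nitrogen

The compounds below may be only part of what the source reports. "The series", "measured", "known", "first", "only" and "open" are said of these compounds alone.

Compound 3 `CC(C(=O)NCc1ccc(C(F)(F)F)nc1N1CCCCCC1)c1ccc(NS(C)(=O)=O)c(F)c1` is one of three compounds tested in a functional assay on CHO-K1 cells for antagonist activity at transient receptor potential cation channel subfamily V member 1 (Homo sapiens), read by FLIPR (on this read-out higher numbers stand for weaker inhibition and lower numbers for stronger inhibition), where compound 3 gives 0.8 nM. On these numbers compound 3 stands second highest of three. Its nearest neighbour is compound 1 `CC(C(=O)NCc1ccc(C(F)(F)F)nc1N1CCC(c2ccccc2)CC1)c1ccc(NS(C)(=O)=O)c(F)c1`, which in this assay gives 0.6 nM; the step of a 1.3-fold higher number from compound 1 to compound 3 (0.12 log units; within the scatter) is too small to count. Furthest away is compound 2 `CCCCOC1CCN(c2nc(C(F)(F)F)ccc2CNC(=O)C(C)c2ccc(NS(C)(=O)=O)c(F)c2)CC1`, which in this assay gives 3.5 nM; here a 4.4-fold lower number from compound 2 to compound 3 (0.64 log units; beyond the scatter). Between those two, a 5.8-fold higher number from compound 1 to compound 2 (0.77 log units; beyond the scatter).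

Compound 4 `CC(C(=O)NCc1ccc(C(F)(F)F)nc1N1CCN(C)CC1)c1ccc(NS(C)(=O)=O)c(F)c1` differs from compound 3 in one place: 4-methylpiperazin-1-yl in place of azepan-1-yl on an aromatic carbon. Of the measured steps, only those that swap the ring on that aromatic carbon bear on it. The swap from compound 1 to compound 3 shows that a change of ring size together with loss of the phenyl substituent left the number unchanged within the scatter, whereas the swap from compound 1 to compound 2 shows that a butoxy substituent on the ring raised the number modestly. Within the data shown here, no measured compound carries a second ring nitrogen or a methyl group on it, so the new change is not directly covered by any measured step. A modest rise in the number is expected, a 10-fold higher number from compound 3 to compound 4 (1.00 log units; beyond the scatter). The estimate for compound 4 in this assay is 8 nM, with a range from 2 nM to 40 nM.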

Compound 4, inhibition constant: 146 nM
Estimate against measurement, compound 4: 18-fold (1.26 log units) below, outside the stated range (above it).
By their numbers in this assay, from the lowest: compounds 1 and 3 (each within the scatter of the next); then compound 2; then compound 4.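

In this assay the ring on this aromatic carbon, next to the ring nitrogen, turns out to matter a great deal: the swap of azepan-1-yl for 4-methylpiperazin-1-yl gives a 180-fold higher number from compound 3 to compound 4 (2.26 log units; beyond the scatter) in a single change, even though both groups count the same number of heavy atoms. The other comparisons agree, with a 240-fold higher number from compound 1 to compound 4 (2.39 log units; beyond the scatter) and a 42-fold higher number from compound 2 to compound 4 (1.62 log units; beyond the scatter) both printed as large, so compound 4 sits apart from all three earlier compounds. Those compounds, each with one nitrogen in this ring, had shown that the position could take quite different groups, including azepan-1-yl and 4-phenylpiperidin-1-yl, with at most a modest shift in the number, and only compound 4 reveals a group here that costs far more.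

The second ring nitrogen and its methyl group enter together, so these compounds cannot separate their contributions; plain piperazin-1-yl, 4-methylpiperidin-1-yl or morpholin-4-yl on the same carbon would be the groups to pull them apart. No measurement at hand speaks to why the step is so large.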